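A few compounds are considered here, and "the series" means these few. Any claim that something is new, unique, unknown or untested is made for them only; others in the source may bear on it.

The measured compounds, each with its reading in a functional assay on PC-3 cells (Homo sapiens) for cytotoxicity, read by MTT assay, with a stated time of 48 h; a lower number here means a stronger inhibitor, a higher number a weaker inhibitor:
compound 1, `COc1cc(C(=O)C2Sc3nnc(-c4cc(OC)c(OC)c(OC)c4)n3NC2c2ccco2)cc(OC)c1OC`, gives 52200 nM;
compound 2, `COc1ccc(C(=O)C2Sc3nnc(-c4cc(OC)c(OC)c(OC)c4)n3NC2c2ccco2)cc1`, gives > 100000 nM;
compound 3, `COc1cc(-c2nnc3n2NC(c2ccco2)C(C(=O)c2ccc([N+](=O)[O-])cc2)S3)cc(OC)c1OC`, gives 27900 nM.

For compound 2 the reading is a limit of this assay, not a number, as the limit of > 100000 nM in this assay, at which 1 of the 3 values shown sits, states. Among the two numbers, compound 3 is separated from compound 1 by a 1.9-fold lower number from compound 1 to compound 3 (0.27 log units; within the scatter), so the two cannot be ordered.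

Compound 4, `COc1cccc(C(=O)C2Sc3nnc(-c4cc(OC)c(OC)c(OC)c4)n3NC2c2ccco2)c1`, has not yet been measured. Its difference from compound 3 is 3-methoxyphenyl in place of 4-nitrophenyl on a carbonyl carbon. Within the data shown here, two measured steps bear on this change. The exchange of the 4-nitrophenyl for a methoxy-bearing ring ran the other way in the measured set: an at least 3.5-fold lower number from compound 2 to compound 3 (0.55 log units; beyond the scatter), so the reverse exchange should raise the number, though only by at least that much, as compound 2 sits at a limit. The other step, an at least 1.9-fold higher number from compound 1 to compound 2 (0.28 log units; that floor lies within the scatter), shows that moving between methoxy patterns on this ring produced no clear step. Compound 4 is therefore expected to give a higher number than compound 3 in this assay, as a 2.7-fold higher number from compound 3 to compound 4 (0.43 log units; beyond the scatter). The estimate for compound 4 is 75000 nM, within the range 30000 nM to 150000 nM, with a real chance that only a limit is reported.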

Compound 4, half-maximal inhibitory concentration: 84600 nM
Compound 4: the middle estimate sits 1.1-fold (0.05 log units) below what was measured, within the range that was stated.
By their numbers in this assay, from the lowest: compounds 3, 1 and 4 (each within the scatter of the next, the first and the last beyond it). At a limit, above all of these: compound 2.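

In this assay, the earlier gap beyond the scatter between compound 3 and a methoxy-bearing ring rested on a limit, and the new result now gives that comparison as a number: a 3.0-fold higher number from compound 3 to compound 4 (0.48 log units; beyond the scatter). The change from 4-nitrophenyl to 3-methoxyphenyl on this carbonyl carbon is therefore a modest measured step, but it is no general rule for nitro against methoxy, as compound 1 goes against it, its own step to compound 3 lying within the scatter, and a 1.6-fold higher number from compound 1 to compound 4 (0.21 log units; within the scatter) leaves 3-methoxyphenyl and 3,4,5-trimethoxyphenyl unordered. Compound 2 gives a limit rather than a number, so an at least 1.1-fold lower number from compound 2 to compound 4 (0.07 log units; that floor lies within the scatter) is only a floor and does not separate 4-methoxyphenyl from 3-methoxyphenyl: the limit of > 100000 nM in this assay, at which 1 of the 4 values shown sits.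

The compounds shown leave open whether a ring carrying an amine or a carboxylic acid at this position would read nearer to 4-nitrophenyl or to the methoxy-bearing rings. They also leave open whether a longer alkyl chain in place of the aromatic ring on the carbonyl carbon would give a number in this assay at all.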